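Removing the benzyl amide from a cytotoxic furan-type core

The compounds below may be only part of what the source reports. "The series", "measured", "known", "first", "only" and "open" are said of these compounds alone.

For the measured compounds named here, compound 3 `C=CC1=C(C(=O)NCc2ccccc2)C(c2ccc(OC)cc2)OC1` is the only member of this small set with a number in a functional assay on SW480 cells (Homo sapiens) for cytotoxicity, read by MTT assay, with a stated time of 24 h; a lower number here means a stronger inhibitor, a higher number a weaker inhibitor: compound 3 gives 39500 nM. Compound 1 `C=CC1=C(C(=O)NC2CCCCC2)C(c2ccc(OC)cc2)OC1` reaches only a limit of the assay, > 100000 nM, not a number. Compound 2 `C=CC1=C(C(=O)Nc2ccc(C)cc2)C(c2ccc(OC)cc2)OC1` likewise gives only a limit, > 100000 nM. The measured steps run from those limits down to compound 3: an at least 2.5-fold lower number from compound 1 to compound 3 (0.40 log units; beyond the scatter) and an at least 2.5-fold lower number from compound 2 to compound 3 (0.40 log units; beyond the scatter), each at least modest. Compound 4 `C=CC1=C(C(=O)O)C(c2ccc(OC)cc2)OC1` differs from compound 3 in one place: hydroxy in place of benzylamino on a carbonyl carbon. Going by the values given here, no measured step exchanges the whole amide for a hydroxy group, so the expectation rests on the fact that the benzyl amide alone produced a number. Compound 4 is expected to give a higher number, a 2.5-fold higher number from compound 3 to compound 4 (0.40 log units; beyond the scatter), estimated at 100000 nM with a range of 40000 nM to 300000 nM.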

Compound 4, half-maximal inhibitory concentration: > 100000 nM
Compound 4 gave a limit, no number; the forecaster's own chance of this, stated with the estimate: 70%; the middle value lies on the limit itself.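

Hydroxy in place of benzylamino on the carbonyl carbon gives an at least 2.5-fold higher number from compound 3 to compound 4 (0.40 log units; beyond the scatter), so the carboxylic acid does not keep the measurable effect of compound 3. Among the groups shown on this carbon, only benzylamino gives a number rather than a limit. The steps to compound 4 from compound 1 and compound 2 cannot be read, because all three compounds end at the same limit: the limit of > 100000 nM in this assay, at which 3 of the 4 values shown sit.

On these data alone, it remains open whether the number depends on the aromatic ring of benzylamino or on the amide nitrogen. A methylamide, a 2-phenylethylamide with its longer chain, or a methyl ester on this carbon would help separate the two.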